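The compounds below may be only part of what the source reports. "The series", "measured", "known", "first", "only" and "open" are said of these compounds alone.

Measured compounds in this series:
- compound 1 `Clc1ccc(-c2cc(-c3ccsc3)nc(-c3ccccc3Cl)c2)o1`: 8070 nM
- compound 2 `Clc1ccc(-c2cc(-c3ccoc3)cc(-c3cccs3)n2)cc1`: 5530 nM
- compound 3 `Clc1ccc(-c2cc(-c3ccoc3)cc(-c3ccsc3)n2)cc1`: 4140 nM

In a functional assay on HeLa cells (Homo sapiens) for cytotoxicity, in the presence of a further agent that is not named here (on this read-out lower numbers stand for stronger inhibition and higher numbers for weaker inhibition), compound 2 stands at the second highest of the three numbers. Its nearest neighbour is compound 3, reached by the step of a 1.3-fold lower number from compound 2 to compound 3 (0.13 log units; within the scatter), which is within the scatter; its furthest neighbour is compound 1, and the gap between those two values also lies within the scatter. On these numbers the three measured compounds cannot be told apart.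

Compound 4 `Clc1ccc(-c2cc(-c3ccc(Cl)o3)cc(-c3cccs3)n2)cc1` is not yet measured. It differs from compound 2 in one place: 5-chlorofuran-2-yl in place of furan-3-yl on an aromatic carbon. Among the compounds with values here, no measured step bears directly on this exchange. Within the data shown here, the only step available, from compound 2 to compound 3, alters a different ring and stays within the scatter. Compound 1 carries a 5-chlorofuran-2-yl group on a differently arranged core, and its value set against that of compound 2 shows no difference beyond the scatter either. Nothing here points to a move in either direction, so the expected step is a 1.0-fold lower number from compound 2 to compound 4 (0.00 log units; within the scatter), i.e. no step beyond the scatter. For compound 4 the estimate in this assay is 5500 nM, with an expected range from 2500 nM to 12000 nM.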

Compound 4, half-maximal inhibitory concentration: 21300 nM
Compound 4: middle estimate off by 3.9-fold (0.59 log units), on the low side, outside the stated range (above it).
By their numbers in this assay, from the lowest: compounds 3, 2 and 1 (each within the scatter of the next); then compound 4.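

In this assay, within the data shown here, the place opposite the ring nitrogen responds to the group it carries: a 3.9-fold higher number from compound 2 to compound 4 (0.59 log units; beyond the scatter) is the first step that lies beyond the scatter, and the higher number means weaker inhibition. Among these compounds, the only earlier step between compounds differing in one place, a 1.3-fold lower number from compound 2 to compound 3 (0.13 log units; within the scatter), changed thiophen-2-yl to thiophen-3-yl at a different place and stayed within the scatter, so the series now holds one exchange that separates two compounds and one that does not. Nothing measured here accounts for the direction or the size of the step from furan-3-yl to 5-chlorofuran-2-yl.

This exchange alters both the chlorine and the point at which the furan ring is attached, and the compounds shown do not separate the two, so it stays open whether plain furan-2-yl would stand with compound 2 or with compound 4. Also open, from the compounds shown here alone, are how an amine or a carboxylic acid on the furan ring would read at this place, and whether the same exchange carries over when thiophen-3-yl stands in place of thiophen-2-yl, as in compound 3.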